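Swapping the benzylic amine arm on a shared core

The source may hold more compounds than are shown below. What is called first, only, known or untested is meant among the compounds shown, and "the series" means these compounds.

Compound 1, `COc1ccc(/C=C\c2cc(OC)c(OC)c(OC)c2)cc1OCc1ccc(CNC(C)(C)C(=O)O)cc1`: in a functional assay on B16-F10 cells (Mus musculus) for antiproliferative activity, read by CCK-8 assay, with a stated time of 48 h (on this read-out higher numbers stand for weaker inhibition and lower numbers for stronger inhibition), compound 1 gives > 10000 nM, a limit of the assay rather than a number.
Compound 2, `COc1ccc(/C=C\c2cc(OC)c(OC)c(OC)c2)cc1OCc1ccc(CN2CCCC[C@@H]2C(=O)O)cc1`: in this assay compound 2 gives > 10000 nM, again a limit.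
Compound 3, `COc1ccc(/C=C\c2cc(OC)c(OC)c(OC)c2)cc1OCc1ccc(CN[C@H](C(=O)O)[C@H](C)O)cc1`: in this assay compound 3 gives > 10000 nM, also a limit.

Compound 1 therefore stands at the limit, as do its two companions; this is the limit of > 10000 nM in this assay, at which 3 of the 3 values shown sit. The three steps among them, a step that the two limits leave unreadable from compound 1 to compound 2, a step that the two limits leave unreadable from compound 1 to compound 3 and a step that the two limits leave unreadable from compound 2 to compound 3, all lie between two limits and have no readable size, so none of them tells how much the benzylic amine arm matters.

Compound 4, `COc1ccc(/C=C\c2cc(OC)c(OC)c(OC)c2)cc1OCc1ccc(CN2CC[C@H](O)C2)cc1`, differs from compound 1 by 3-hydroxypyrrolidin-1-yl in place of (1-carboxy-1-methylethyl)amino on a saturated chain carbon bound to an aromatic carbon. Among the measured compounds shown here, none of the measured steps keeps the arm as simple as a 3-hydroxypyrrolidin-1-yl: every measured compound carries a carboxy group on that arm, and compound 4 carries none. For the measured compounds named here, no measured step therefore bears on this change with a readable size, and the expectation for compound 4 rests only on the limit at which compound 1 sits.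

The step of an at least 3.3-fold lower number from compound 1 to compound 4 (0.52 log units; beyond the scatter) is accordingly estimated with wide uncertainty. Compound 4 is expected to give about 3000 nM in this assay, in a range from 200 nM to 20000 nM.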

Compound 4, half-maximal inhibitory concentration: > 10000 nM
Compound 4: a limit, no number; the forecaster's own chance of this, stated with the estimate: 45%; at least 3.3-fold (0.52 log units) between middle value and limit.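

In this assay compound 4 gives > 10000 nM, again a limit and not a number. Its steps from compound 1, compound 2 and compound 3 all lie between two limits and cannot be read. The series ends where it began: the limit of > 10000 nM in this assay, at which 4 of the 4 values shown sit.

The compounds shown leave open how much the benzylic amine arm matters on the shared core, and whether any arm gives a readable number.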